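Iridoid glycoside esters on breast cancer cells: an unreadable series

The source may report more compounds than this note shows. Statements on the series, on what has been measured and on what is new or still open speak of the compounds shown alone.

Compound 1: `C/C=C1/[C@H](O[C@@H]2O[C@H](CO)[C@@H](O)[C@H](O)[C@H]2O)OC=C(C(=O)OC)[C@H]1CC(=O)OC` gives > 15000 nM, a limit of the assay.
Compound 2: `C/C=C1/[C@H](O[C@@H]2O[C@H](CO)[C@@H](O)[C@H](O)[C@H]2O)OC=C(C(=O)OC)[C@H]1CC(=O)NCCC` gives > 20000 nM, a limit of the assay.
Compound 3: `C/C=C1/[C@H](O[C@@H]2O[C@H](CO)[C@@H](O)[C@H](O)[C@H]2O)OC=C(C(=O)OC)[C@H]1CC(=O)OCCc1ccc(F)cc1` gives > 20000 nM, a limit of the assay.

All three compounds share one glycoside core and differ only in the group attached at the carbonyl at the end of the side chain. In a functional assay on SK-BR-3 cells (Homo sapiens) for antiproliferative activity, read by MTT assay, with a stated time of 72 h (a lower number here means a stronger inhibitor, a higher number a weaker inhibitor), none of them reaches a measurable number. The step that the two limits leave unreadable from compound 1 to compound 3 and the step that the two limits leave unreadable from compound 2 to compound 3 therefore cannot be read; the evidence is only the limit of > 15000 nM in this assay, at which 1 of the 3 values shown sits, and (the limit of > 20000 nM in this assay, at which 2 of the 3 values shown sit). Compound 3 thus stands with the weakest kind of result this assay can report, and so do the other two.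

Compound 4, `C/C=C1/[C@H](O[C@@H]2O[C@H](CO)[C@@H](O)[C@H](O)[C@H]2O)OC=C(C(=O)OC)[C@H]1CC(=O)OCc1ccc2c(c1)OCCO2`, carries the change (2,3-dihydro-1,4-benzodioxin-6-yl in place of 4-fluorobenzyl on a saturated chain carbon bound to an oxygen next to a carbonyl group). Going by the values given here, no measured step bears on this change in a readable way, since every comparison ends at a limit. The step of a number no higher from compound 3 to compound 4 (the limit leaves the size open) is therefore expected to be no readable change. Compound 4 is estimated at 20000 nM, with a range from 8000 nM to 50000 nM, and most likely this assay will again report only a limit for compound 4.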

Compound 4, half-maximal inhibitory concentration: > 15000 nM
Compound 4: a limit, no number; the forecaster's own chance of this, stated with the estimate: 80%; the middle value does not contradict the limit.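

In this assay compound 4 gives > 15000 nM, which is a limit of the assay and not a number. Its steps from compound 1, compound 2 and compound 3 therefore cannot be read. The compounds shown leave open how active each one truly is, and whether the group on the side-chain carbonyl changes the result in this assay at all.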